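The source may report more compounds than this note shows. Statements on the series, on what has been measured and on what is new or still open speak of the compounds shown alone.

Among the compounds with values here, compound 2 `O=C(COc1ccc(Cl)c(Cl)c1)NNC(=S)NCc1ccc(-c2ccccc2)cc1` is one of two compounds measured in an assay on isolated protein for inhibition of A disintegrin and metalloproteinase with thrombospondin motifs 5 (Homo sapiens), read by spectrophotometry, with stated times of 10 min and 3 h; a higher number here means a weaker inhibitor, a lower number a stronger inhibitor; compound 2 gives 1200 nM, and compound 1 `O=C(COc1ccccc1Cl)NNC(=S)NCc1ccc(-c2ccccc2)cc1` gives 1900 nM. Within the data shown here, the one measured step, a 1.6-fold lower number from compound 1 to compound 2 (0.20 log units; within the scatter), changes only the chlorinated ring and stays within the scatter. Compound 3 `O=C(CNc1ccc(Cl)cc1)NNC(=S)NCc1ccc(-c2ccccc2)cc1` differs from compound 2 by (4-chlorophenyl)amino in place of 3,4-dichlorophenoxy on a saturated chain carbon bound to a carbonyl carbon. Among the measured compounds shown here, that step touches the same region of the molecule but swaps the linking oxygen for an amino group, a change no measured step covers; the only nearby step being within the scatter, compound 3 is expected to show a step of a 1.3-fold higher number from compound 2 to compound 3 (0.10 log units; within the scatter), with an estimated value of 1500 nM in this assay, between 500 nM and 4500 nM.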

Compound 3, half-maximal inhibitory concentration: 6300 nM
Beside the measured number, compound 3's estimate is 4.2-fold (0.62 log units) below it, outside the stated range (above it).
By their numbers in this assay, from the lowest: compounds 2 and 1 (each within the scatter of the next); then compound 3.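

Replacing the ether-linked ring with (4-chlorophenyl)amino gives a 5.3-fold higher number from compound 2 to compound 3 (0.72 log units; beyond the scatter) and also a 3.3-fold higher number from compound 1 to compound 3 (0.52 log units; beyond the scatter). Within the data shown here, changing the chlorines on the phenoxy ring had stayed within the scatter, so this is the first step at this position that clearly moves the number, and it moves towards weaker inhibition. Nothing available explains this loss.

The step changes both the linking atom and the chlorine pattern, so their contributions cannot be separated. A 4-chlorophenoxy or (3,4-dichlorophenyl)amino group would help to tell them apart.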